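From compound 2 to compound 3: a side-chain exchange

The source may hold more compounds than are shown below. What is called first, only, known or untested is meant among the compounds shown, and "the series" means these compounds.

Compound 1 (`CN1CCCN(CCNc2nccc(-c3c(-c4cccc(O)c4)nc4sccn34)n2)S1(=O)=O`): 1790 nM
Compound 2 (`O=S(=O)(NCCCNc1nccc(-c2c(-c3cccc(O)c3)nc3sccn23)n1)c1cccc(F)c1`): 2030 nM

In a functional assay on cells (Panel melanoma (Carcinoma cell lines), Homo sapiens) for inhibition, read by sulforhodamine B assay, with a stated time of 48 h (on this read-out lower numbers stand for stronger inhibition and higher numbers for weaker inhibition), compound 2 gives 2030 nM and cannot be told apart from compound 1 (1790 nM). Compound 3 (`O=S(=O)(NCCNc1nccc(-c2c(-c3cccc(O)c3)nc3sccn23)n1)c1ccc(F)cc1`) differs from compound 2 by one exchange (((4-fluorophenyl)sulfonyl)amino in place of (((3-fluorophenyl)sulfonyl)amino)methyl on a saturated chain carbon, two bonds along the chain from a nitrogen on an aromatic ring). Among the measured compounds shown here, the only measured step (a 1.1-fold higher number from compound 1 to compound 2 (0.05 log units; within the scatter)) changed the group at this same place and stayed within the scatter. A similar outcome is therefore expected here in this assay, with no direction favoured. The expected step (a 1.1-fold lower number from compound 2 to compound 3 (0.03 log units; within the scatter)) lies within the scatter. For compound 3 the estimated value is 1900 nM (estimated range 700 nM to 5000 nM).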

Compound 3, half-maximal inhibitory concentration: 1490 nM
Estimate against measurement, compound 3: 1.3-fold (0.11 log units) above, and the stated range covers the measured number.
By their numbers in this assay, from the lowest: compounds 3, 1 and 2 (each within the scatter of the next).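

In this assay, the exchange of (((3-fluorophenyl)sulfonyl)amino)methyl for ((4-fluorophenyl)sulfonyl)amino gives a 1.4-fold lower number from compound 2 to compound 3 (0.13 log units; within the scatter), and the comparison with the earlier group gives a 1.2-fold lower number from compound 1 to compound 3 (0.08 log units; within the scatter), so three different groups at this place on the saturated chain carbon cannot be told apart. This single exchange removes the methyl and moves the fluorine label from 3-fluorophenyl to 4-fluorophenyl together, so the two changes cannot be separated. No evidence is available on what lies behind these numbers. On these data alone, it remains open whether a group of another kind here, such as a primary amine or a carboxylic acid, would give a step beyond the scatter.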